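Swapping a Methoxy for a Cyano on the Benzyl Ring

The source may hold more compounds than are shown below. What is called first, only, known or untested is meant among the compounds shown, and "the series" means these compounds.

Of the compounds shown here, three have been measured in a physicochemical assay for solubility, using the shake flask method, in simulated intestinal fluid, measured as kinetic solubility, with a stated time of 2 h, at 25 degrees C, at pH 6.5; a higher number here means a more soluble compound, a lower number a less soluble compound. Compound 1 `CCOC(=O)c1nc(C)c2c(c1N)C(=O)N(Cc1ccccc1)C2=O` sits at the lower limit of this assay, giving < 5000 nM, which is a limit rather than a number. Compound 2 `Cc1nc(C(=O)NC#N)c(N)c2c1C(=O)N(Cc1ccccc1)C2=O` gives 185000 nM. Going by the values given here, the only step that can be read between measured compounds is an at least 37-fold higher number from compound 1 to compound 2 (1.56 log units; beyond the scatter), a change made on a carbonyl carbon. Compound 3 `COc1ccc(CN2C(=O)c3c(C)nc(-c4nc(C)no4)c(N)c3C2=O)cc1` is also reported only as a limit, < 5000 nM. This is worth keeping in mind: the limit of < 5000 nM in this assay, at which 2 of the 3 values shown sit. So compound 3 stands at the bottom of what this assay reports, with no number of its own, while compound 2 stands clearly above that limit.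

Compound 4 `Cc1noc(-c2nc(C)c3c(c2N)C(=O)N(Cc2ccc(C#N)cc2)C3=O)n1` differs from compound 3 in one place: cyano in place of methoxy on an aromatic carbon. Cut one bond further out, the change reads 4-methoxybenzyl to 4-cyanobenzyl.

Among the compounds with values here, no measured step here exchanges a methoxy for a cyano, and the single measured step sits at a different place in the molecule, so it gives no direct guide. With nothing to suggest a move, the expectation for compound 4 is a step within the scatter, a step that the limit leaves unreadable from compound 3 to compound 4. Compound 4 is therefore estimated at 3000 nM, with a range from 800 nM to 15000 nM, and most likely reported again only as a limit.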

Compound 4, solubility: < 5000 nM
Compound 4: a limit, no number; the forecaster's own chance of this, stated with the estimate: 70%; the middle value lies beyond the limit too.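

In this assay compound 4 gives < 5000 nM as a limit, not a number. Compound 3 is a limit too, so no step can be read between compound 3 and compound 4: the limit of < 5000 nM in this assay, at which 3 of the 4 values shown sit. The compounds shown leave open where compound 3 and compound 4 truly lie, and whether cyano in place of methoxy shifts the solubility at all.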